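Moving the methyl around a cyclohexyl amide

This account rests on a few compounds, and the source may have more. Where it says the series, first, only, none or still open, it means among the compounds named here.

Measured compounds:
compound 1 `CC1CC1C(=O)N1CCc2nc(C#Cc3ccccc3)sc2C1` — 9.4 nM
compound 2 `COC1CC(C(=O)N2CCc3nc(C#Cc4ccccc4)sc3C2)C1` — 640 nM
compound 3 `CC1CCC(C(=O)N2CCc3nc(C#Cc4ccccc4)sc3C2)CC1` — 190 nM

The three compounds share a core and differ only in the ring attached to the carbonyl carbon. In an assay on HEK293 cells for positive allosteric modulation of metabotropic glutamate receptor 5 (Homo sapiens), read by FLIPR, with a stated time of 1 h (on this read-out lower numbers stand for an effect already at smaller amounts and higher numbers for an effect only at larger amounts of compound), compound 1 gives 9.4 nM, compound 2 gives 640 nM and compound 3 gives 190 nM. Compound 3 therefore stands second highest of the three numbers: its nearest neighbour is compound 2, from which a 3.4-fold lower number from compound 2 to compound 3 (0.53 log units; beyond the scatter), and its furthest is compound 1, from which a 20-fold higher number from compound 1 to compound 3 (1.31 log units; beyond the scatter). The step of a 68-fold higher number from compound 1 to compound 2 (1.83 log units; beyond the scatter) shows how strongly this assay reacts to exchanging the ring itself.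

Compound 4 `CC1CCCC(C(=O)N2CCc3nc(C#Cc4ccccc4)sc3C2)C1` is not yet measured. The change is 3-methylcyclohexyl in place of 4-methylcyclohexyl on a carbonyl carbon. Among the measured compounds shown here, no measured step moves a methyl within an otherwise unchanged ring; the measured steps all swap one ring for another of different size, and both steps onto compound 3 were large. The change to compound 4 is smaller in kind than any of them, so a step within the scatter is expected, a 1.1-fold higher number from compound 3 to compound 4 (0.02 log units; within the scatter). Compound 4 is therefore estimated at 200 nM in this assay, with a range from 60 nM to 650 nM.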

Compound 4, half-maximal effective concentration: 100 nM
Beside the measured number, compound 4's estimate is 2.0-fold (0.30 log units) above it; the range from low to high includes it.
By their numbers in this assay, from the lowest: compound 1; then compounds 4 and 3 (each within the scatter of the next); then compound 2.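

In this assay, among the compounds shown here, replacing 4-methylcyclohexyl with 3-methylcyclohexyl on the carbonyl carbon gives the first step here that keeps the same atoms and only joins them differently (a 1.9-fold lower number from compound 3 to compound 4 (0.28 log units; within the scatter)), and it stays within the usual scatter, so these two compounds do not separate on this change. The ring exchanges keep their standing with the new compound (an 11-fold higher number from compound 1 to compound 4 (1.03 log units; beyond the scatter); a 6.4-fold lower number from compound 2 to compound 4 (0.81 log units; beyond the scatter)), so the 2-methylcyclopropyl of compound 1 and the 3-methoxycyclobutyl of compound 2 each remain apart, beyond the scatter, from 3-methylcyclohexyl as well as from 4-methylcyclohexyl. Nothing available gives a reason for any of these steps.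

The compounds shown leave open whether the methyl on the cyclohexyl ring matters at all, a question that an unsubstituted cyclohexyl or a dimethylcyclohexyl on the carbonyl carbon would address. Also open, on these data alone, is what sets the 2-methylcyclopropyl of compound 1 apart from the larger rings, on which a plain cyclopropyl or a cyclopentyl in the same place would bear.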